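The compounds below may be only part of what the source reports. "The series", "measured", "known", "first", "only" and "open" are said of these compounds alone.

All numbers below come from a functional assay, read by spectrophotometry, with a stated time of 20 min; a lower number here means a stronger inhibitor, a higher number a weaker inhibitor.

Measured so far:
- compound 1 `COc1ccc(-c2oc3ccccc3c(=O)c2C)cc1` gives 100 ug/mL
- compound 2 `Cc1c(-c2ccc(O)cc2)oc2ccccc2c1=O` gives 104 ug/mL
- compound 3 `COc1ccccc1-c1oc2ccccc2c(=O)c1C` gives 143 ug/mL

Compound 1 and compound 3 are built from the same atoms joined differently; the difference between the two cores is not broken down here. Compound 1 and compound 2 differ in one place, (hydrogen in place of methyl on an oxygen on an aromatic ring), and the step between them is a 1.0-fold higher number from compound 1 to compound 2 (0.02 log units; within the scatter), so this change left the number where it was in that pair. Compound 3 and compound 2 are within the scatter of each other, as are compound 3 and compound 1.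

Compound 4 `Cc1c(-c2ccccc2O)oc2ccccc2c1=O` is not yet measured. It differs from compound 3 by hydrogen in place of methyl on an oxygen on an aromatic ring; the place is described in the same words as for compound 1 and compound 2, so it is the same change on the other core. Among the measured compounds shown here, only one earlier instance of the change is available, so the expectation rests on a single pair. Because the step of a 1.0-fold higher number from compound 1 to compound 2 (0.02 log units; within the scatter) stayed within the scatter, the step from compound 3 to compound 4 is expected to be similarly small, a 1.0-fold higher number from compound 3 to compound 4 (0.01 log units; within the scatter). Compound 4 is therefore expected to give about 145 ug/mL in this assay, most likely between 80 ug/mL and 260 ug/mL.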

Compound 4, half-maximal inhibitory concentration: 79.4 ug/mL
Compound 4: the middle estimate sits 1.8-fold (0.26 log units) above what was measured; measured number below the stated range.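

In this assay, hydrogen in place of methyl on an oxygen on an aromatic ring gives a 1.8-fold lower number from compound 3 to compound 4 (0.26 log units; within the scatter). Set beside the same change on the core of compound 1, the two steps cannot be told apart: the same change on two cores in this assay, a 1.0-fold higher number (0.02 log units; within the scatter) from compound 1 to compound 2 and a 1.8-fold lower number (0.26 log units; within the scatter) from compound 3 to compound 4, 1.9-fold (0.27 log units) apart, within the scatter of two such steps. This shows that, on these two cores, going from methoxy to hydroxy produces no step beyond the scatter, but two pairs cannot show that the change would behave the same way on a further core, and neither step can be read as a real gain or loss in inhibition.

The comparison covers only methoxy and hydroxy, so no listed step yet ties any group to a change larger than the scatter. Still open, going by these compounds, is whether a longer chain on that oxygen, or an amine or a carboxylic acid in place of the methoxy or hydroxy group, would move the number beyond the scatter and whether such a step would carry between the two cores.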